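The compounds below may be only part of what the source reports. "The series", "measured", "known", "first", "only" and "open" are said of these compounds alone.

Among the compounds with values here, compound 3 `CS(=O)(=O)NC1CCN(C2CN(CCC3(c4ccc(Cl)c(Cl)c4)CCC(=O)N(CC4CC4)C3)C2)CC1` gives 10 nM in an assay on isolated protein (artery, Oryctolagus cuniculus) with Substance-P receptor (Homo sapiens) as the target (on this read-out higher numbers stand for weaker binding and lower numbers for tighter binding), the second highest of the three numbers measured so far. Compound 1 `O=C1CCC(CCN2CC(N3CCNCC3)C2)(c2ccc(Cl)c(Cl)c2)CN1CC1CC1` gives 12.6 nM, and compound 2 `CNS(=O)(=O)N1CCN(C2CN(CCC3(c4ccc(Cl)c(Cl)c4)CCC(=O)N(CC4CC4)C3)C2)CC1` gives 3.16 nM. Compound 4 `O=C1CCN(C2CN(CCC3(c4ccc(Cl)c(Cl)c4)CCC(=O)N(CC4CC4)C3)C2)CC1` has not yet been measured. It differs from compound 3 in one place: 4-oxopiperidin-1-yl in place of 4-(methanesulfonamido)piperidin-1-yl on a saturated ring carbon. Within the data shown here, two measured steps concern the same position. The step of a 1.3-fold lower number from compound 1 to compound 3 (0.10 log units; within the scatter) was small, whereas a 3.2-fold higher number from compound 2 to compound 3 (0.50 log units; beyond the scatter) was a modest loss. Among the measured compounds shown here, neither step involves the 4-oxopiperidin-1-yl group, and no measured compound carries it, so the direct evidence is thin. The changes tried at this position have all stayed modest. The expected step is therefore a 1.5-fold higher number from compound 3 to compound 4 (0.18 log units; within the scatter), modest at most. Compound 4 is estimated at 15 nM, with a range from 5 nM to 50 nM.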

Compound 4, dissociation constant: 1.26 nM
The estimate for compound 4 lay 12-fold (1.08 log units) above the measured number, outside the stated range (below it).
By their numbers in this assay, from the lowest: compound 4; then compound 2; then compounds 3 and 1 (each within the scatter of the next).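

In this assay, the 4-oxopiperidin-1-yl group gives the tightest binding of the four compounds (a 7.9-fold lower number from compound 3 to compound 4 (0.90 log units; beyond the scatter); a 2.5-fold lower number from compound 2 to compound 4 (0.40 log units; beyond the scatter); a 10-fold lower number from compound 1 to compound 4 (1.00 log units; beyond the scatter)). The position on the saturated ring carbon therefore tolerates a group with fewer heavy atoms than 4-(methanesulfonamido)piperidin-1-yl, and the gain exceeds any earlier step. Nothing available explains this gain.

On these data alone, whether the carbonyl itself matters remains open. A plain piperidin-1-yl or a 4-hydroxypiperidin-1-yl group at this position would help separate the carbonyl's contribution from that of the ring.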